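Trimming a Basic Amine at the Benzylic Sulfonamide Arm

The source may hold more compounds than are shown below. What is called first, only, known or untested is meant among the compounds shown, and "the series" means these compounds.

Going by the values given here, compound 1 `COc1cc(CN(CC(=O)NCc2ccccc2Cl)S(=O)(=O)c2ccc(CN3CCN(C)CC3)cc2)ccc1OCC(C)C` is one of two compounds measured in an assay on WI 38 cells for displacement of a labelled ligand from B1 bradykinin receptor (Homo sapiens); a lower number here means a stronger inhibitor, a higher number a weaker inhibitor; here compound 1 gives 11 nM. The other, compound 2 `COCCCNC(=O)CN(CCOc1ccc2c(c1)CCC2)S(=O)(=O)c1ccc(Cl)cc1Cl`, gives 1210 nM in this assay, a higher number than compound 1 by a gap well beyond the scatter, so compound 1 has the lower of the two numbers. Compound 3 `COc1cc(CN(CC(=O)NCc2ccccc2Cl)S(=O)(=O)c2ccc(CN(C)C)cc2)ccc1OCC(C)C` has not been measured. It differs from compound 1 in one place: dimethylamino in place of 4-methylpiperazin-1-yl on a saturated chain carbon bound to an aromatic carbon. Among the compounds with values here, no measured pair shows this change, so the expected step from compound 1 to compound 3, a 1.8-fold higher number from compound 1 to compound 3 (0.26 log units; within the scatter), is small, within the scatter. Compound 3 is therefore estimated at 20 nM, between 5 nM and 80 nM.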

Compound 3, inhibition constant: 93 nM
The estimate for compound 3 lay 4.7-fold (0.67 log units) below the measured number, outside the stated range (above it).
By their numbers in this assay, from the lowest: compound 1; then compound 3; then compound 2.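

In this assay, putting dimethylamino in place of 4-methylpiperazin-1-yl on a saturated chain carbon bound to an aromatic carbon gives an 8.5-fold higher number from compound 1 to compound 3 (0.93 log units; beyond the scatter), so this position is sensitive to which amine it carries. In this single pair, the group with the ring and more heavy atoms has the lower number. Nothing measured here explains the step. On these data alone, it remains open whether the ring or the second ring nitrogen matters more. Piperidin-1-yl or morpholin-4-yl at this position would help separate the two.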